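Swapping the thiophene group on compound 2

The source may report more compounds than this note shows. Statements on the series, on what has been measured and on what is new or still open speak of the compounds shown alone.

Measured in a functional assay on DU-145 cells (Homo sapiens) for inhibition, read by trypan blue exclusion, with a stated time of 96 h; a higher number here means a weaker inhibitor of growth, a lower number a stronger inhibitor of growth:
compound 1 `Cc1ccc(S(=O)(=O)/C(=C/c2sccc2C)C(=O)c2ccc(Cl)cc2)cc1` gives 10000 nM
compound 2 `Cc1ccc(S(=O)(=O)/C(=C/c2sccc2C)C(=O)c2ccc(Br)cc2)cc1` gives 25000 nM
compound 3 `Cc1cc(C)cc(/C=C(\C(=O)c2ccc(Cl)cc2)S(=O)(=O)c2ccc(Br)cc2)c1` gives 10000 nM

Of these three, compound 2 has the highest number (25000 nM) and so is the weakest growth inhibitor. Compound 4 `Cc1ccc(S(=O)(=O)/C(=C/c2ccc(F)cc2F)C(=O)c2ccc(Br)cc2)cc1` is not yet measured. It departs from compound 2 by one exchange: 2,4-difluorophenyl in place of 3-methylthiophen-2-yl on a double-bonded chain carbon bound to a double-bonded chain carbon. That is, 2,4-difluorophenyl stands in place of 3-methylthiophen-2-yl on a double-bonded chain carbon bound to a double-bonded chain carbon.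

Within the data shown here, no measured step covers this exchange. Among the measured compounds shown here, the only step available, a 2.5-fold higher number from compound 1 to compound 2 (0.40 log units; beyond the scatter), is modest and concerns bromo in place of chloro on an aromatic carbon, elsewhere in the molecule. Compound 3 carries another group at the changing place, but it differs in other places too, and it gives 10000 nM. On that thin evidence, a modest move to a lower number is expected (a 2.1-fold lower number from compound 2 to compound 4 (0.32 log units; beyond the scatter)) in this assay. Compound 4 is estimated at 12000 nM in a range from 4000 nM to 35000 nM at the upper end.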

Compound 4, concentration for 50% growth inhibition: > 100000 nM
Compound 4: a limit, no number; the forecaster's own chance of this, stated with the estimate: 15%; middle value at least 8.3-fold (0.92 log units) from the limit.
By their numbers in this assay, from the lowest: compounds 1 and 3 (each within the scatter of the next); then compound 2. At a limit, above all of these: compound 4.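

In this assay compound 4 gives > 100000 nM, which is a limit of the assay and not a number. The earlier step concerned only a halogen elsewhere in the molecule, whereas putting 2,4-difluorophenyl in place of 3-methylthiophen-2-yl brings an at least 4.0-fold higher number from compound 2 to compound 4 (0.60 log units; beyond the scatter), so the group on this double-bonded chain carbon clearly matters for growth inhibition. On these data alone, how far the change reaches past that step stays unknown, since the read-out ends at a limit: the limit of > 100000 nM in this assay, at which 1 of the 4 values shown sits.

This one exchange replaces a five-membered aromatic ring holding sulfur and a methyl group with a six-membered carbon ring holding two fluorines, so the compounds shown cannot tell which of these differences counts. As far as these compounds go, what a plain phenyl or a pyridine ring would give at this place remains open.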